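A few compounds are considered here, and "the series" means these few. Any claim that something is new, unique, unknown or untested is made for them only; others in the source may bear on it.

Measured so far in a functional assay on MCF7 cells (Homo sapiens) for inhibition, read by MTT assay; a lower number here means a stronger inhibitor of growth, a higher number a weaker inhibitor of growth:
- compound 1 `CC1=C(/C=C/C(C)=C/C=C/C(C)=C\C(=O)Nc2ccc(O)cc2)C(C)(C)CCC1n1ccnc1`: 1990 nM
- compound 2 `CC1=C(/C=C/C(C)=C/C=C/C(C)=C\C(=O)NCc2ccccc2)C(C)(C)CCC1n1ccnc1`: 9770 nM

Compound 2, at 9770 nM, has the higher of the two numbers in this assay and so is the weaker growth inhibitor of the pair. The next compound is compound 3 `CC1=C(/C=C/C(C)=C/C=C/C(C)=C\C(=O)Nc2ccccc2O)C(C)(C)CCC1n1ccnc1`, which is related to compound 2 by this change: 2-hydroxyphenyl in place of benzyl on an amide-type nitrogen. In short, 2-hydroxyphenyl replaces benzyl on an amide-type nitrogen.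

Within the data shown here, only one measured step bears on this change: a 4.9-fold higher number from compound 1 to compound 2 (0.69 log units; beyond the scatter). That step is modest but beyond the scatter, and it puts benzyl in place of 4-hydroxyphenyl on the same nitrogen. Compound 3 goes the opposite way, from benzyl back to a hydroxyphenyl group, but with 2-hydroxyphenyl rather than 4-hydroxyphenyl. Among the measured compounds shown here, no measured compound carries 2-hydroxyphenyl, so the earlier step is only a rough guide. A shift to a lower number is expected, of similar or somewhat smaller size.

The expected change is a 3.3-fold lower number from compound 2 to compound 3 (0.51 log units; beyond the scatter).

For compound 3 the estimated value is 3000 nM, with an expected range of 1200 nM to 8000 nM.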

Compound 3, concentration for 50% growth inhibition: 1090 nM
Beside the measured number, compound 3's estimate is 2.8-fold (0.44 log units) above it; measured number below the stated range.
By their numbers in this assay, from the lowest: compounds 3 and 1 (each within the scatter of the next); then compound 2.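

In this assay the change from benzyl to 2-hydroxyphenyl on the amide-type nitrogen gives a 9.0-fold lower number from compound 2 to compound 3 (0.95 log units; beyond the scatter) and is the larger of the two steps away from benzyl seen at this position, so both hydroxyphenyl compounds now sit apart from compound 2. Moving from 4-hydroxyphenyl to 2-hydroxyphenyl gives a 1.8-fold lower number from compound 1 to compound 3 (0.26 log units; within the scatter) and stays within the scatter, so these compounds do not separate the two placements of the hydroxyl on the ring in this assay. Nothing at hand explains why either hydroxyphenyl group differs from benzyl.

The gap to compound 2 could go with the hydroxyl or with the extra carbon that links the ring to the nitrogen in benzyl, and these compounds change both together, so plain phenyl and hydroxybenzyl are the groups that would pull the two apart. Also open, as far as these compounds go, is whether the hydroxyl itself is needed on the ring or whether another group, such as an amine or a carboxylic acid, would give a similar number on the shared core.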